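Anilide Swap on a Dinitro Bis-benzylidene Scaffold

A few compounds are considered here, and "the series" means these few. Any claim that something is new, unique, unknown or untested is made for them only; others in the source may bear on it.

Measured compounds in a functional assay on L1210 cells (Mus musculus) for cytotoxicity; a lower number here means a stronger inhibitor, a higher number a weaker inhibitor:
compound 1 `O=C(/C=C/C(=O)N1C/C(=C\c2ccccc2)C(=O)/C(=C/c2ccccc2)C1)Nc1ccc(Cl)c(Cl)c1` gives 7500 nM
compound 2 `O=C(/C=C/C(=O)N1C/C(=C\c2ccc([N+](=O)[O-])cc2)C(=O)/C(=C/c2ccc([N+](=O)[O-])cc2)C1)Nc1ccc(Cl)c(Cl)c1` gives 1700 nM
compound 3 `COc1ccc(NC(=O)/C=C/C(=O)N2C/C(=C\c3ccccc3)C(=O)/C(=C/c3ccccc3)C2)cc1` gives 6800 nM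

Compound 2 has the lowest number of the three in this assay; compound 3 lies higher and compound 1 somewhat higher again, both gaps beyond the scatter. Compound 4 `Cc1cccc(C)c1NC(=O)/C=C/C(=O)N1C/C(=C\c2ccc([N+](=O)[O-])cc2)C(=O)/C(=C/c2ccc([N+](=O)[O-])cc2)C1` is compound 2 with one change: 2,6-dimethylphenyl in place of 3,4-dichlorophenyl on an amide-type nitrogen. Among the measured compounds shown here, the only measured step that touches the same place is the one from compound 1 to compound 3, where the aryl on the amide-type nitrogen was exchanged and the number stayed put, a 1.1-fold lower number from compound 1 to compound 3 (0.04 log units; within the scatter). That step suggests the anilide aryl has little influence on the read-out within this set, while the larger shift between compound 1 and compound 2 is tied to the nitro groups, which compound 4 keeps. For compound 4 in this assay the expected step is therefore a 1.2-fold higher number from compound 2 to compound 4 (0.07 log units; within the scatter), none beyond the scatter. Compound 4 is estimated at 2000 nM, with a range from 800 nM to 5000 nM.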

Compound 4, half-maximal inhibitory concentration: 690 nM
Compound 4: the middle estimate sits 2.9-fold (0.46 log units) above what was measured, and the stated range ends above it.
By their numbers in this assay, from the lowest: compound 4; then compound 2; then compounds 3 and 1 (each within the scatter of the next).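

On the core of compound 2, the aryl on the amide-type nitrogen does register in this assay: 2,6-dimethylphenyl in place of 3,4-dichlorophenyl gives a 2.5-fold lower number from compound 2 to compound 4 (0.39 log units; beyond the scatter) and lies beyond the scatter, whereas the earlier exchange at this position, a 1.1-fold lower number from compound 1 to compound 3 (0.04 log units; within the scatter) on the core of compound 1, did not. The two groups match in heavy atoms, aromatic ring and hydrogen-bond counts, and differ in chlorine against carbon and in the numbering of their substituents. No measurement shown here explains the step.

Among the compounds shown, 2,6-dimethylphenyl occurs only with the nitro groups and 4-methoxyphenyl only without them, so it remains open whether the core or the entering group sets the size of the step. On these data alone, how an aminophenyl or a carboxyphenyl would read at this position also remains open.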